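The source may report more compounds than this note shows. Statements on the series, on what has been measured and on what is new or still open speak of the compounds shown alone.

Measured so far:
- compound 1 `O=C1NC(=O)/C(=C\c2cccc(Cl)c2)N1`
- compound 2 `O=C1NC(=O)/C(=C\c2cccc(Br)c2)N1`

In a functional assay on the whole organism with Rattus norvegicus as the target (a higher number here means that more compound is needed for the effect, a lower number that less compound is needed), compound 1 gives only a limit, > 200 mg/kg. In this assay compound 2 likewise gives only a limit, > 200 mg/kg. Among the measured compounds shown here, compound 2 therefore stands at the limit of this assay and not at a number; the one further value shown, that of compound 1, is also a limit, and (the limit of > 200 mg/kg in this assay, at which 2 of the 2 values shown sit). For the measured compounds named here, the single step among the measured compounds, a step that the two limits leave unreadable from compound 1 to compound 2, is therefore not readable as a size in either direction, and it gives no foothold for the scatter either.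

Compound 3 `O=C1NC(=O)/C(=C\c2cccc(C(F)(F)F)c2)N1` is not yet measured in this assay. It differs from compound 2 in one place: trifluoromethyl in place of bromo on an aromatic carbon. Going by the values given here, no measured step with a readable size bears on this exchange; the only step available, a step that the two limits leave unreadable from compound 1 to compound 2, concerns a different group and is itself unreadable. What the numbers do show is that both measured compounds sit at the limit of this assay, and nothing in them points to compound 3 falling clearly inside the measurable range. The expected step is a number no higher from compound 2 to compound 3 (the limit leaves the size open), that is, no size beyond the scatter in either direction. The estimate for compound 3 is 200 mg/kg, with a range from 60 mg/kg to 600 mg/kg, and most likely again reported only as a limit.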

Compound 3, dose for half-maximal effect: > 200 mg/kg
Compound 3 ended at the assay's limit (the forecaster's own chance of this, stated with the estimate: 70%); the middle value lies on the limit itself.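

In this assay compound 3 gives > 200 mg/kg as a limit and not a number. Among the compounds shown here, no step among compound 1, compound 2 and compound 3 can be read as a size: the limit of > 200 mg/kg in this assay, at which 3 of the 3 values shown sit.

The compounds shown leave open whether this assay gives a number for any member of this series, and how chloro, bromo and trifluoromethyl compare.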